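From Isopropyl to Trifluoromethyl on One Aromatic Carbon

The source may report more compounds than this note shows. Statements on the series, on what has been measured and on what is new or still open speak of the compounds shown alone.

Within the data shown here, in a functional assay on KBVIN cells (Homo sapiens) for antiproliferative activity, read by sulforhodamine B assay, with a stated time of 3 days (a higher number here means that more compound is needed for the effect, a lower number that less compound is needed), compound 1 `CCC1=C(O)c2c(oc(-c3ccc(C)cc3)cc2=O)C(CC)(CC)C1=O` gives 0.08 uM, while compound 2 `CCC1=C(O)c2c(oc(-c3ccc(C(C)C)cc3)cc2=O)C(CC)(CC)C1=O` gives 1.08 uM, the higher of the two numbers so far. Compound 3 `CCC1=C(O)c2c(oc(-c3ccc(C(F)(F)F)cc3)cc2=O)C(CC)(CC)C1=O` keeps the shared core and carries trifluoromethyl in place of isopropyl on an aromatic carbon. Among the measured compounds shown here, only one measured step bears on this change: isopropyl in place of methyl gave a 14-fold higher number from compound 1 to compound 2 (1.13 log units; beyond the scatter), which is large and beyond the scatter. That step shows that the group at this place can matter greatly, but a single step sets no rule for a third group. Compound 3 is therefore expected to land between the two measured compounds, nearer neither extreme. The expected change is a 2.7-fold lower number from compound 2 to compound 3 (0.43 log units; beyond the scatter), towards a lower number. For compound 3 the estimated value is 0.4 uM, within a range of 0.1 uM to 1.5 uM.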

Compound 3, concentration for half-maximal effect: 10.4 uM
Estimate against measurement, compound 3: 26-fold (1.41 log units) below, and the stated range ends below it.
By their numbers in this assay, from the lowest: compound 1; then compound 2; then compound 3.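

In this assay, trifluoromethyl does not fall among the earlier numbers: the swap from isopropyl gives a 9.6-fold higher number from compound 2 to compound 3 (0.98 log units; beyond the scatter) and leaves compound 3 with the highest number of the three. Set against methyl, the same group gives a 130-fold higher number from compound 1 to compound 3 (2.11 log units; beyond the scatter) and so shows how widely the result can swing on this one aromatic carbon, with methyl in compound 1 still needing the least compound. Nothing shown here accounts for why trifluoromethyl behaves this way.

Both larger replacements shown raise the number from compound 1, but three groups are too few to set a rule for this place. A plain hydrogen, a chlorine atom, a methoxy group or an ethyl chain on this carbon could still show whether any group gives a lower number than methyl.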